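Swapping the Imidazole Substituent on the Chain Carbon

A few compounds are considered here, and "the series" means these few. Any claim that something is new, unique, unknown or untested is made for them only; others in the source may bear on it.

Values measured in a functional assay on HUVEC cells (Homo sapiens), read by scintillation counting and thymidine incorporation, with a stated time of 24 h (a lower number here means a stronger inhibitor, a higher number a weaker inhibitor), so far are these:
compound 1 `CCC(C)n1ncn(-c2ccc(N3CCN(c4ccc(OC[C@@H]5CO[C@@](CN(C)C)(c6ccc(Cl)cc6Cl)O5)cc4)CC3)cc2)c1=O` gives 1400 nM
compound 2 `CCC(C)n1ncn(-c2ccc(N3CCN(c4ccc(OC[C@@H]5CO[C@@](Cn6ccnc6-c6ccccc6)(c6ccc(Cl)cc6Cl)O5)cc4)CC3)cc2)c1=O` gives 136 nM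

Of these two numbers, compound 2 holds the lower, at 136 nM against the higher number of compound 1. For the measured compounds named here, the only measured step is a 10-fold lower number from compound 1 to compound 2 (1.01 log units; beyond the scatter) and lies beyond the scatter. It is large, and it came with 2-phenyl-1H-imidazol-1-yl in place of dimethylamino on a saturated chain carbon bound to a saturated ring carbon.

Compound 3 `CCC(C)n1ncn(-c2ccc(N3CCN(c4ccc(OC[C@@H]5CO[C@@](Cn6cc(C(F)(F)F)nc6C)(c6ccc(Cl)cc6Cl)O5)cc4)CC3)cc2)c1=O` changes that same place, with 2-methyl-4-(trifluoromethyl)-1H-imidazol-1-yl in place of 2-phenyl-1H-imidazol-1-yl. The counted difference is 2-methyl-4-(trifluoromethyl)-1H-imidazol-1-yl in place of 2-phenyl-1H-imidazol-1-yl on a saturated chain carbon bound to a saturated ring carbon and shows that the six-membered aromatic ring of carbon only leaves while the five-membered aromatic ring stays. Going by the values given here, no measured step exchanges one imidazole for another, so the evidence is indirect. Compound 3 is therefore expected to give back part of the gain seen in a 10-fold lower number from compound 1 to compound 2 (1.01 log units; beyond the scatter) but not all of it. The expected change is a 2.2-fold higher number from compound 2 to compound 3 (0.34 log units; beyond the scatter) in this assay and points to a higher number. Compound 3 is estimated at 300 nM and expected to fall between 90 nM and 1000 nM.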

Compound 3, half-maximal inhibitory concentration: 441 nM
Compound 3: the middle estimate sits 1.5-fold (0.17 log units) below what was measured; the measured number falls inside the stated range.
By their numbers in this assay, from the lowest: compound 2; then compound 3; then compound 1.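

In this assay the step of a 3.2-fold higher number from compound 2 to compound 3 (0.51 log units; beyond the scatter) shows that this position on the chain carbon is sensitive to what the imidazole carries: with the five-membered aromatic ring kept and the six-membered aromatic ring of carbon only gone, part of the earlier gain is lost. Yet the step of a 3.2-fold lower number from compound 1 to compound 3 (0.50 log units; beyond the scatter) shows that an imidazole without any phenyl still stands clear of dimethylamino, so the gain over compound 1 does not depend on the phenyl ring alone, and the two steps are close in size, placing compound 3 about midway on the scale set by compound 1 and compound 2. Nothing measured on these compounds accounts for either step, so the result stays a plain observation of numbers.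

The methyl and the trifluoromethyl entered together as the phenyl left, so the compounds shown cannot divide the loss among these changes, and a 2-methyl-1H-imidazol-1-yl alone or a plain 1H-imidazol-1-yl would be needed to separate them. As far as these compounds go, whether a 2-phenyl-1H-imidazol-1-yl that also bears a trifluoromethyl would keep the number of compound 2 also stays open.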